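A few compounds are considered here, and "the series" means these few. Any claim that something is new, unique, unknown or untested is made for them only; others in the source may bear on it.

Measured compounds in the series:

Compound 1 `CC(C)=CCC/C(C)=C/CC/C(C)=C\Cn1cc(-c2ccccc2)nn1` gives 6.95 in a physicochemical assay for lipophilicity, measured as octanol-water partition; on this read-out higher numbers stand for higher lipophilicity and lower numbers for lower lipophilicity.
Compound 2 `CCCc1cn(C/C=C(\C)CC/C=C(\C)CCC=C(C)C)nn1` gives 6.5 in this assay.
Compound 3 `COC(=O)c1cn(C/C=C(\C)CC/C=C(\C)CCC=C(C)C)nn1` gives 5.25 in this assay.

Compound 3 stands lowest of the three numbers; its nearest neighbour is compound 2, whose value lies beyond the scatter above it, and the furthest is compound 1, whose value lies further still above it, also beyond the scatter.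

Compound 4 `CC(C)=CCC/C(C)=C/CC/C(C)=C/Cn1cc(-c2ccccc2)nn1` is not yet measured. It differs from compound 3 as follows: phenyl in place of methoxycarbonyl on an aromatic carbon.

For the measured compounds named here, the one measured step that bears on the substituent at this position is a number 1.25 log units lower from compound 2 to compound 3 (beyond the scatter), which shows that putting methoxycarbonyl on this aromatic carbon brings the number down by a large margin relative to an all-carbon group. Going by the values given here, no step is recorded for phenyl against methoxycarbonyl, but compound 1 carries the same phenyl group on the same core as compound 4, and the values of compound 1 and compound 3 show a gap of the same order as the recorded step, in the opposite sense to that seen on going to methoxycarbonyl.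

A large rise is therefore expected from compound 3 to compound 4, estimated as a number 1.65 log units higher from compound 3 to compound 4 (beyond the scatter). Compound 4 is expected to give about 6.9, in the range 6.5 to 7.3, close to compound 1 because compound 1 gives 6.95.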

Compound 4, partition coefficient: 6.95
The estimate for compound 4 lay 0.05 log units below the measured number; low and high end bracket the measured number.
By their numbers in this assay, from the lowest: compound 3; then compound 2; then compounds 1 and 4 (each within the scatter of the next).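

In this assay, phenyl in place of methoxycarbonyl on the aromatic carbon gives a number 1.70 log units higher from compound 3 to compound 4 (beyond the scatter), and phenyl in place of propyl gives a number 0.45 log units higher from compound 2 to compound 4 (beyond the scatter). With both steps beyond the scatter, the three groups now fall in a single order on the shared core, with methoxycarbonyl lowest, propyl in the middle and phenyl highest, and the gap between propyl and phenyl is the smaller part of that span. The drawn configuration of the double bond makes no difference that this read-out can detect, with no change at the digits printed from compound 1 to compound 4 (within the scatter), and that pair is the only direct comparison of the two configurations in the series: the fact that compounds 1 and 4 differ only in the configuration as drawn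

The compounds shown leave open where a carboxylic acid, an amine or a longer chain on this aromatic carbon would fall in that order. They also leave open whether the double-bond configuration stays without effect on the number when propyl or methoxycarbonyl stands in place of phenyl.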